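The source may report more compounds than this note shows. Statements on the series, on what has been measured and on what is new or still open speak of the compounds shown alone.

Measured so far:
- compound 1, `Cc1ccc(-c2nc3c(N)nc(NCc4cccs4)nc3s2)o1`: 15.3 nM
- compound 2, `Nc1nc(NCc2ccncc2)nc2sc(-c3ccco3)nc12`: 827 nM

In an assay on CHO cells for displacement of a labelled ligand from adenosine receptor A3 (Homo sapiens), read by scintillation counting, with a stated time of 120 min (a lower number here means a stronger inhibitor, a higher number a weaker inhibitor), compound 1 gives 15.3 nM. In this assay, for the measured compounds named here, compound 2 gives 827 nM, the higher of the two numbers known for the series, and the gap to compound 1 lies well beyond the scatter of the method. Going by the values given here, no pair of the measured compounds differs in only one place, so the two numbers show only that the shared core carries one substituent on the chain nitrogen that reads strong and one that reads weak; no step can be isolated from them.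

Compound 3, `Nc1nc(NCc2cccnc2)nc2sc(-c3ccco3)nc12`, is the next compound and has not been measured. It differs from compound 2 by pyridin-3-yl in place of pyridin-4-yl on a saturated chain carbon bound to a nitrogen on an aromatic ring. Among the compounds with values here, with no measured step of this kind to lean on, the size of the change is open. Since the heavy-atom count and the acceptor count are unchanged and only the ring attachment moves, a modest movement is expected in this assay, more likely downward than upward, but not far beyond the scatter.

On that basis compound 3 is estimated at 400 nM, with a range of 120 nM to 1500 nM. The step this implies, a 2.1-fold lower number from compound 2 to compound 3 (0.32 log units; beyond the scatter), is an expectation and not a measurement.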

Compound 3, inhibition constant: 18.2 nM
The estimate for compound 3 lay 22-fold (1.34 log units) above the measured number, and the stated range ends above it.
By their numbers in this assay, from the lowest: compounds 1 and 3 (each within the scatter of the next); then compound 2.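

In this assay, the series gains its first readable step at this position: a 45-fold lower number from compound 2 to compound 3 (1.66 log units; beyond the scatter) with pyridin-3-yl in place of pyridin-4-yl on a saturated chain carbon bound to a nitrogen on an aromatic ring. The step is large even though the two groups have the same heavy atoms, hydrogen-bond donors and hydrogen-bond acceptors by count, so in this pair the number follows how the pyridine ring is joined and not only what it contains. Nothing measured here bears on why the two forms of the ring read so differently.

Still open, on these data alone, is whether pyridin-4-yl or pyridin-3-yl is the exception at this position, a question that pyridin-2-yl, an unsubstituted phenyl ring or a longer chain carrying the pyridin-3-yl group could help settle. For the compounds shown here, compound 1 differs from compound 3 in more than one place, so that pair gives no step, and whether the effect of moving the ring attachment carries over to other substituents on the shared core remains unknown.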